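Adding a Methyl to the Indole Core of Compound 2

The source may report more compounds than this note shows. Statements on the series, on what has been measured and on what is new or still open speak of the compounds shown alone.

Of the compounds shown here, two have been measured so far. Compound 1 `Cc1[nH]c2ccccc2c1C1CC(c2ccncc2)=NO1` gives 45100 nM in a functional assay on LNCaP C4-2 cells (Homo sapiens) for inhibition, read by MTT assay, with a stated time of 48 h; a higher number here means a weaker inhibitor, a lower number a stronger inhibitor. Compound 2 `Clc1ccc(Cn2cc(C3CC(c4ccncc4)=NO3)c3ccccc32)cc1` gives 11400 nM in this assay, the lower of the two numbers and beyond the scatter from compound 1. Compound 3 `Cc1c(C2CC(c3ccncc3)=NO2)c2ccccc2n1Cc1ccc(Cl)cc1` has not yet been measured. It differs from compound 2 by methyl in place of hydrogen on an aromatic carbon. Going by the values given here, no measured pair shows this change, so the step from compound 2 to compound 3 is expected to stay within the scatter, in either direction, as a 1.1-fold lower number from compound 2 to compound 3 (0.06 log units; within the scatter). Compound 3 is therefore estimated at 10000 nM, with a range from 3000 nM to 35000 nM.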

Compound 3, half-maximal inhibitory concentration: 2500 nM
Compound 3: the middle estimate sits 4.0-fold (0.60 log units) above what was measured, outside the stated range (below it).
By their numbers in this assay, from the lowest: compound 3; then compound 2; then compound 1.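

In this assay, methyl in place of hydrogen on this aromatic carbon gives a 4.6-fold lower number from compound 2 to compound 3 (0.66 log units; beyond the scatter), so even this single added carbon at the position changes the reading beyond the scatter. Going by these compounds alone, with that methyl in place, 4-chlorobenzyl in place of hydrogen on the aromatic nitrogen gives an 18-fold lower number from compound 1 to compound 3 (1.26 log units; beyond the scatter), the first single-place reading of that group. Nothing here explains either step. The compounds shown leave open how an ethyl group, a longer chain or an amine on this carbon would read, and whether the methyl step holds with groups other than 4-chlorobenzyl on the nitrogen.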